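A few compounds are considered here, and "the series" means these few. Any claim that something is new, unique, unknown or untested is made for them only; others in the source may bear on it.

Of the compounds shown here, three have been measured in a functional assay on MDA-MB-468 cells (Homo sapiens) for inhibition, with a stated time of 72 h; a higher number here means a weaker inhibitor of growth, a lower number a stronger inhibitor of growth. Compound 1, `N#Cc1cc(-c2nc3c(F)cccc3s2)ccc1N`, gives 80 nM. Compound 2, `C[Si](C)(C)C#Cc1cc(-c2nc3c(F)cccc3s2)ccc1N`, gives 230 nM. Compound 3, `N#Cc1cc(-c2nc3ccccc3s2)ccc1N`, gives 340 nM. Compound 2 and compound 3 differ from compound 1 in one place each. From compound 1 to compound 2 the change is a group of 6 heavy atoms (5 carbon, 1 silicon; no ring) in place of a group of 2 heavy atoms (1 carbon, 1 nitrogen; no ring), on an aromatic carbon, and it gave a 2.9-fold higher number from compound 1 to compound 2 (0.46 log units; beyond the scatter). From compound 1 to compound 3 the change is hydrogen in place of fluoro on an aromatic carbon, and it gave a 4.3-fold higher number from compound 1 to compound 3 (0.63 log units; beyond the scatter). The values of compound 2 and compound 3 lie within the usual scatter of each other, so nothing separates them.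

Compound 4, `C[Si](C)(C)C#Cc1cc(-c2nc3ccccc3s2)ccc1N`, has not yet been measured. It differs from compound 3 by a group of 6 heavy atoms (5 carbon, 1 silicon; no ring) in place of a group of 2 heavy atoms (1 carbon, 1 nitrogen; no ring), on an aromatic carbon. Among the compounds with values here, this is the same kind of change as the one from compound 1 to compound 2, at the same position of the same ring; the neighbouring group that the two descriptions call by different words is the same group in both pairs. The cores of the two pairs differ as described by hydrogen in place of fluoro on an aromatic carbon.

Given the step already seen between compound 1 and compound 2, compound 4 is expected to move from compound 3 by a step of similar size, a 2.9-fold higher number from compound 3 to compound 4 (0.47 log units; beyond the scatter). In this assay, within the data shown here, compound 4 is therefore estimated at 1000 nM, with a likely range from 400 nM to 2500 nM, because the step of a 2.9-fold higher number from compound 1 to compound 2 (0.46 log units; beyond the scatter) is the only guide available.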

Compound 4, concentration for 50% growth inhibition: 560 nM
For compound 4 the middle estimate is 1.8-fold (0.25 log units) above the measured one, and the stated range covers the measured number.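

In this assay, putting the group of 6 heavy atoms in place of cyano on the core without fluoro gives a 1.6-fold higher number from compound 3 to compound 4 (0.22 log units; within the scatter), and this step does not differ measurably from the one seen on the fluorinated core: the same change on two cores in this assay, a 2.9-fold higher number (0.46 log units; beyond the scatter) from compound 1 to compound 2 and a 1.6-fold higher number (0.22 log units; within the scatter) from compound 3 to compound 4, 1.7-fold (0.24 log units) apart, within the scatter of two such steps. The second change, hydrogen in place of fluoro, gives a 2.4-fold higher number from compound 2 to compound 4 (0.39 log units; beyond the scatter) when the group of 6 heavy atoms is present, and it too matches its earlier counterpart: the same change on two cores in this assay, a 4.3-fold higher number (0.63 log units; beyond the scatter) from compound 1 to compound 3 and a 2.4-fold higher number (0.39 log units; beyond the scatter) from compound 2 to compound 4, 1.7-fold (0.24 log units) apart, within the scatter of two such steps. Both changes therefore carried from one core to the other in these four compounds, but this rests on a single pair of steps for each change, so it does not fix the exact size of either step, does not explain either one, and does not show that they would hold on any further core.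

The compounds shown leave open how other groups would behave at the same place, such as a plain ethynyl, a methyl or a bromo in place of cyano, and whether chloro would act as fluoro does on the core. They also leave open whether these steps would hold beyond this assay, in other cell lines.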